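The compounds below may be only part of what the source reports. "The series", "measured", "known", "first", "only" and "open" are said of these compounds alone.

In a functional assay on B16 cells (Mus musculus) for inhibition (on this read-out lower numbers stand for stronger inhibition and higher numbers for weaker inhibition), compound 3 (`COc1cc2oc(=O)cc(COC(=O)/C=C/c3ccc(Cl)cc3)c2cc1OC`) gives > 10 ug/mL, which is a limit and not a number. Compound 1 (`CC(C)=CC(=O)OCc1cc(=O)oc2ccc(Cl)cc12`) gives > 10 ug/mL, also a limit. Compound 2 (`C/C=C/C(=O)OCc1cc(=O)oc2cc(OC)c(OC)cc12`) gives > 10 ug/mL, again a limit. Among the compounds with values here, compound 3 therefore has no measured number, and the series so far offers only (the limit of > 10 ug/mL in this assay, at which 3 of the 3 values shown sit).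

Compound 4 (`COc1cc2oc(=O)cc(COC(=O)/C=C/c3ccc(N)cc3)c2cc1OC`) has amino in place of chloro on an aromatic carbon of the six-membered aromatic ring, para to a large group: amino in place of chloro on an aromatic carbon.

Within the data shown here, the only measured step that bears on this change is a step that the two limits leave unreadable from compound 2 to compound 3. It touches the same chain, but it gives no size and no direction. Among the measured compounds shown here, no measured step supports a shift in either direction, so the expectation stays with the limit shared by the series. The expected change is a step that the limit leaves unreadable from compound 3 to compound 4, with no step beyond the scatter anticipated. For compound 4 the estimated value is 12 ug/mL, with an expected range of 5 ug/mL to 30 ug/mL.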

Compound 4, half-maximal inhibitory concentration: > 10 ug/mL
Compound 4: a limit, no number; the forecaster's own chance of this, stated with the estimate: 70%; the middle value lies beyond the limit too.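

In this assay compound 4 gives > 10 ug/mL, a limit and not a number. No new step can be read between compound 4 and either compound 2 or compound 3. The compounds shown leave open whether any change among them alters inhibition, and the series offers only: the limit of > 10 ug/mL in this assay, at which 4 of the 4 values shown sit.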